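The source may report more compounds than this note shows. Statements on the series, on what has been measured and on what is new or still open speak of the compounds shown alone.

Compound 1 `Cn1cc2c(Cl)nc(NC(=O)c3ccccc3)nc2n1` gives 23600 nM in an assay on CHO cells for displacement of a labelled ligand from adenosine receptor A3 (Homo sapiens), read by scintillation counting, with a stated time of 3 h; on this read-out higher numbers stand for weaker inhibition and lower numbers for stronger inhibition. Compound 2 `CC(C)n1cc2c(Cl)nc(NC(=O)c3ccccc3)nc2n1` gives 12800 nM in this assay, which amounts to a 1.8-fold lower number from compound 1 to compound 2 (0.27 log units; within the scatter). Compound 3 `Cn1cc2c(Cl)nc(NC(=O)c3ccc(F)cc3)nc2n1` gives 31900 nM in this assay, the highest of the three numbers, though the step that separates it from the nearest number is only a 1.4-fold higher number from compound 1 to compound 3 (0.13 log units; within the scatter) and within the scatter, while its gap to compound 2 lies beyond it. Compound 4 `CC(C)n1cc2c(Cl)nc(NC(=O)c3ccc(F)cc3)nc2n1` differs from compound 3 by isopropyl in place of methyl on an aromatic nitrogen. Among the compounds with values here, the one measured step of this kind, a 1.8-fold lower number from compound 1 to compound 2 (0.27 log units; within the scatter), stayed within the scatter, so no change beyond the scatter is expected, at most a small lowering. For compound 4 the expected step is a 1.8-fold lower number from compound 3 to compound 4 (0.25 log units; within the scatter) in this assay. Compound 4 is therefore estimated to give 18000 nM in this assay, between 8000 nM and 40000 nM.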

Compound 4, inhibition constant: > 60000 nM
Compound 4: only a limit was reported (the forecaster's own chance of this, stated with the estimate: 5%); middle value at least 3.3-fold (0.52 log units) away from the limit.
By their numbers in this assay, from the lowest: compounds 2, 1 and 3 (each within the scatter of the next, the first and the last beyond it). At a limit, above all of these: compound 4.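

For compound 4 the reading in this assay is a limit, > 60000 nM, so the steps that reach it give only floors. With fluoro present, isopropyl in place of methyl gives an at least 1.8-fold higher number from compound 3 to compound 4 (0.27 log units; that floor lies within the scatter), and with isopropyl present, fluoro in place of hydrogen gives an at least 4.6-fold higher number from compound 2 to compound 4 (0.67 log units; beyond the scatter). What each change does therefore depends on whether the other is present: the same change on two cores in this assay, a 1.8-fold lower number (0.27 log units; within the scatter) from compound 1 to compound 2 and an at least 1.8-fold higher number (0.27 log units; that floor lies within the scatter) from compound 3 to compound 4, at least 3.4-fold (0.54 log units) apart, beyond the scatter of two such steps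

As far as these compounds go, how far compound 4 lies past its limit remains open. So does whether an ethyl group on that nitrogen, or a methoxy group or an amine in place of fluoro, would behave the same way.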